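This account rests on a few compounds, and the source may have more. Where it says the series, first, only, none or still open, it means among the compounds named here.

Three related compounds have been tested in a functional assay on cells (Pituitary gland cell) with growth hormone secretagogue receptor type 1 (Rattus norvegicus) as the target; a higher number here means that more compound is needed for the effect, a lower number that less compound is needed. They share one core and differ only in what hangs from the amine nitrogen. Compound 1 `CC(C)(N)CCC(=O)N[C@@H]1CCc2ccccc2N(Cc2ccc(-c3ccccc3-c3nn[nH]n3)cc2)C1=O` gives 3 uM. Compound 2 `N[C@@H]1CCc2ccccc2N(Cc2ccc(-c3ccccc3-c3nn[nH]n3)cc2)C1=O`, with a hydrogen on that nitrogen in place of a side chain, gives 9 uM. Compound 3 `NCCC(=O)N[C@@H]1CCc2ccccc2N(Cc2ccc(-c3ccccc3-c3nn[nH]n3)cc2)C1=O` gives 2 uM, the lowest of the three numbers, though its gap to compound 1 is within the scatter and only compound 2 stands clearly apart, as a 4.5-fold lower number from compound 2 to compound 3 (0.65 log units; beyond the scatter) shows.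

Compound 4 `CC(C)(CC(=O)N[C@@H]1CCc2ccccc2N(Cc2ccc(-c3ccccc3-c3nn[nH]n3)cc2)C1=O)NCc1ccccc1` has not yet been measured. It differs from compound 3 by 1-(benzylamino)-1-methylethyl in place of aminomethyl on a saturated chain carbon bound to a carbonyl carbon. Among the compounds with values here, two measured steps bear on this. The step of a 1.5-fold lower number from compound 1 to compound 3 (0.18 log units; within the scatter) shows that exchanging amino for 1-amino-1-methylethyl changes little. The step of a 4.5-fold lower number from compound 2 to compound 3 (0.65 log units; beyond the scatter) shows that the side chain itself matters. Within the data shown here, nothing among the measured compounds tells what the benzylamino part does, so the expectation rests mainly on the first of these steps and carries a wide range. The expected step is a 1.5-fold higher number from compound 3 to compound 4 (0.18 log units; within the scatter), meaning no change that can be told from the scatter. Compound 4 is therefore estimated at 3 uM, between 0.7 uM and 15 uM.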

Compound 4, concentration for half-maximal effect: 65 uM
For compound 4 the middle estimate is 22-fold (1.34 log units) below the measured one; measured number above the stated range.
By their numbers in this assay, from the lowest: compounds 3 and 1 (each within the scatter of the next); then compound 2; then compound 4.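

In this assay, within the data shown here, the saturated chain carbon bound to a carbonyl carbon proves far less forgiving than the earlier compounds suggested: placing 1-(benzylamino)-1-methylethyl there in place of aminomethyl gives a 33-fold higher number from compound 3 to compound 4 (1.51 log units; beyond the scatter), a much larger step than any seen before. The comparison with the other side chain that carries two methyl groups points the same way, with 1-(benzylamino)-1-methylethyl in place of 2-amino-2-methylpropyl giving a 22-fold higher number from compound 1 to compound 4 (1.34 log units; beyond the scatter), so methyl branching in a side chain does not by itself bring a number this high. Nothing measured here explains why this change raises the number so sharply.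

The new group brings its benzyl and its two methyl groups together, so the compounds shown leave open which of these parts, or which combination of them, goes with the higher number. A 2-(benzylamino)ethyl chain, which keeps the benzyl without the methyl groups, and a 2-amino-2-methylpropyl chain on the carbonyl carbon, which keeps the methyl groups with a plain amine, would pull the two apart.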